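This account rests on a few compounds, and the source may have more. Where it says the series, first, only, none or still open, it means among the compounds named here.

Measured compounds:
compound 1 `CCNC(=O)CC[C@H](NS(=O)(=O)c1ccc([N+](=O)[O-])cc1)C(=O)O` — 4800 nM
compound 2 `CC(C)NC(=O)CC[C@H](NS(=O)(=O)c1ccc([N+](=O)[O-])cc1)C(=O)O` — 5970 nM
compound 3 `CC(C)CNC(=O)CC[C@H](NS(=O)(=O)c1ccc([N+](=O)[O-])cc1)C(=O)O` — 5140 nM

In an assay for inhibition of matrix metalloproteinase-9 (Homo sapiens), with stated times of 1 h, 1 min and 30 min (a lower number here means a stronger inhibitor, a higher number a weaker inhibitor), compound 3 gives a number that sits with the other two: it is within the scatter of compound 1 and of compound 2. Compound 4 `CCCCCNC(=O)CC[C@H](NS(=O)(=O)c1ccc([N+](=O)[O-])cc1)C(=O)O` is the next member; the change from compound 3 is butyl in place of isopropyl on a saturated chain carbon bound to an amide-type nitrogen. The steps already seen on the amide nitrogen substituent are a 1.2-fold higher number from compound 1 to compound 2 (0.09 log units; within the scatter), a 1.1-fold higher number from compound 1 to compound 3 (0.03 log units; within the scatter) and a 1.2-fold lower number from compound 2 to compound 3 (0.07 log units; within the scatter), each within the scatter. Replacing one small alkyl by another with one more carbon has so far moved nothing beyond noise, so no step beyond the scatter is expected in this assay. Compound 4 is therefore estimated at 5000 nM, with a range of 2500 nM to 10000 nM, a step of a 1.0-fold lower number from compound 3 to compound 4 (0.01 log units; within the scatter).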

Compound 4, half-maximal inhibitory concentration: 6800 nM
Estimate against measurement, compound 4: 1.4-fold (0.13 log units) below; low and high end bracket the measured number.
By their numbers in this assay, from the lowest: compounds 1, 3, 2 and 4 (each within the scatter of the next).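

In this assay the series now reaches pentyl on the amide-type nitrogen with no step beyond the scatter, whether read against the isobutyl (a 1.3-fold higher number from compound 3 to compound 4 (0.12 log units; within the scatter)), the isopropyl (a 1.1-fold higher number from compound 2 to compound 4 (0.06 log units; within the scatter)) or the ethyl compound (a 1.4-fold higher number from compound 1 to compound 4 (0.15 log units; within the scatter)). Among these four compounds, neither chain length nor branching separates the numbers. No measurement on hand accounts for this flat result. Still open, on these data alone, is whether a chain longer than pentyl, or an amine, a carboxylic acid or a phenyl ring on this nitrogen substituent, would produce a step beyond the scatter.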